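Urea series: 4-methoxyphenyl replacing 3-chlorophenyl on the urea

This account rests on a few compounds, and the source may have more. Where it says the series, first, only, none or still open, it means among the compounds named here.

Two ureas sharing one core have been measured in an assay on isolated protein for inhibition of serine/threonine-protein kinase PLK1 (Homo sapiens), read by radiometric assay and 33P incorporation, with a stated time of 40 min, tested at 20 uM, in the presence of a further agent that is not named here; a lower number here means less inhibition, a higher number more inhibition at the concentration tested (going by the name of the read-out). Compound 1 `CCNc1cc(-c2ccc(NC(=O)Nc3ccc(OC)cc3)cc2C)ccn1` gives 45.8%. Compound 2 `CCNc1cc(-c2ccc(NC(=O)Nc3cccc(Cl)c3)cc2F)ccn1` gives 72.7%, the higher of the two numbers, and its distance from compound 1 lies beyond the usual scatter. Within the data shown here, compound 1 and compound 2 differ in two places at once, so the two values say only that the pair as a whole is separated, not which change carries the separation.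

Compound 3 `CCNc1cc(-c2ccc(NC(=O)Nc3ccc(OC)cc3)cc2F)ccn1` is not yet measured. Relative to compound 2 the change is 4-methoxyphenyl in place of 3-chlorophenyl on an amide-type nitrogen. Compound 3 carries the same 4-methoxyphenyl urea end as compound 1, while the remainder of the core matches compound 2. Among the measured compounds shown here, no single-change step has been measured in this assay, so the size of this step can only be expected, not read from a neighbour.

The expectation is a drop in this assay, with compound 2 at 72.7% as the starting point; the step is estimated at a number 17.7 percentage points lower from compound 2 to compound 3 (beyond the scatter). Compound 3 is accordingly expected at 55%, with a range from 35% to 75%, reflecting that compound 1 at 45.8% shares the urea end but not the remainder of the core.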

Compound 3, a percentage reported as inhibition, at one concentration (the size of the read-out at that concentration, not a potency): 47.1%
Beside the measured number, compound 3's estimate is 7.9 percentage points above it, and the stated range covers the measured number.
By their numbers in this assay, from the lowest: compounds 1 and 3 (each within the scatter of the next); then compound 2.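

In this assay the urea end now has a single-change step: 4-methoxyphenyl in place of 3-chlorophenyl on the amide-type nitrogen gives a number 25.6 percentage points lower from compound 2 to compound 3 (beyond the scatter) with the rest of the core held constant. Among these compounds, with 4-methoxyphenyl on the urea, the other single change, fluoro in place of methyl on an aromatic carbon, gives a number 1.3 percentage points higher from compound 1 to compound 3 (within the scatter) and so shows no separation at this position, leaving the urea end as the only single change here with a step beyond the scatter. No measurement at hand explains either step.

As far as these compounds go, whether fluoro and methyl also read alike with 3-chlorophenyl on the urea remains open, as does whether the larger step follows the loss of the chlorine or the arrival of the methoxy, which an unsubstituted phenyl on the same nitrogen would help to separate. From the compounds shown here alone, how this nitrogen responds to other kinds of group, such as a phenyl carrying an amine or a carboxylic acid, is also open, and all of these readings are inhibition at one concentration rather than potencies.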